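Furan-to-thiophene swap on the fused bicyclic core

A few compounds are considered here, and "the series" means these few. Any claim that something is new, unique, unknown or untested is made for them only; others in the source may bear on it.

In a functional assay on HeLa cells (Homo sapiens) for cytotoxicity, read by MTT assay (a lower number here means a stronger inhibitor, a higher number a weaker inhibitor), compound 1 `CCOC(=O)C12C(=O)OCC=C1COC2c1ccc(Br)cc1` gives 48700 nM and compound 2 `CCOC(=O)C12C(=O)OCC=C1COC2c1ccco1` gives 28300 nM; the step of a 1.7-fold lower number from compound 1 to compound 2 (0.24 log units; within the scatter), so the two numbers are not distinguishable. Compound 3 `CCOC(=O)C12C(=O)OCC=C1COC2c1cccs1` carries thiophen-2-yl in place of furan-2-yl on a saturated ring carbon. Going by the values given here, the only step that bears on this change is the aryl swap from compound 1 to compound 2, which stayed within the scatter; no step beyond the scatter is expected in this assay. The step of a 1.1-fold lower number from compound 2 to compound 3 (0.05 log units; within the scatter) is therefore the estimate, and compound 3 is expected to give about 25000 nM, within 10000 nM to 65000 nM.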

Compound 3, half-maximal inhibitory concentration: 30400 nM
Estimate against measurement, compound 3: 1.2-fold (0.08 log units) below; the measured number falls inside the stated range.
By their numbers in this assay, from the lowest: compounds 2, 3 and 1 (each within the scatter of the next).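

In this assay, thiophen-2-yl on this saturated ring carbon adds a second five-membered aromatic ring to the comparison, and a 1.1-fold higher number from compound 2 to compound 3 (0.03 log units; within the scatter) stays within the scatter. Against 4-bromophenyl, a 1.6-fold lower number from compound 1 to compound 3 (0.20 log units; within the scatter) also stays within the scatter, so the three groups at this carbon cannot be told apart. Nothing available bears on the reason for this. As far as these compounds go, whether an amine or a carboxylic acid on the aromatic ring, or a saturated cyclohexyl group in its place, would give a step beyond the scatter remains open. Also open, from the compounds shown here alone, is whether changing the ethoxycarbonyl group would do so.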